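A few compounds are considered here, and "the series" means these few. Any claim that something is new, unique, unknown or untested is made for them only; others in the source may bear on it.

Notes on the series. Compound 1 `COc1ccc(-c2cc(/C=C/C(=O)c3ccc(N)cc3)[nH]n2)cc1` and compound 2 `COc1cc(-c2cc(/C=C/C(=O)c3ccc(N)cc3)[nH]n2)cc(OC)c1OC` share one core and differ only in the methoxy pattern on the ring that carries the core. In a functional assay on UACC-62 cells (Homo sapiens) for cytotoxicity, read by sulforhodamine B assay, with a stated time of 48 h, tested at 1 uM (on this read-out higher numbers stand for a weaker effect at the one concentration tested and lower numbers for a stronger effect), compound 2 gives 86%, and in the same assay compound 1 gives 79%; the gap between these two numbers lies within the usual scatter, so on the numbers shown compound 2 cannot be set apart from compound 1 — both stand for a weak effect at the one concentration tested.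

Compound 3 `COc1ccc(-c2cc(/C=C/C(=O)c3ccc(N)cc3)[nH]n2)cc1OC` has not yet been measured. It differs from compound 2 by hydrogen in place of methoxy on an aromatic carbon. Among the measured compounds shown here, no step between two measured compounds matches this change, so only the two values above can guide an expectation. Since compound 1 and compound 2 sit within the scatter of each other, the step from compound 2 to compound 3 is expected to be small, a number 4 percentage points lower from compound 2 to compound 3 (within the scatter), with no direction beyond the scatter. Compound 3 is therefore estimated at 82%, between 66% and 96%.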

Compound 3, a percentage reported as activity, at one concentration (the size of the read-out at that concentration, not a potency): 95%
The estimate for compound 3 lay 13 percentage points below the measured number; measured number inside the range.
By their numbers in this assay, from the lowest: compounds 1, 2 and 3 (each within the scatter of the next, the first and the last beyond it).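

In this assay, hydrogen in place of methoxy at this position, ortho to a methoxy group and meta to a large group, gives a number 9 percentage points higher from compound 2 to compound 3 (within the scatter) and so cannot be told apart from repeat scatter. Among the compounds shown here, the change of methoxy in place of hydrogen on an aromatic carbon gives a number 16 percentage points higher from compound 1 to compound 3 (beyond the scatter) and is the first step to pass beyond the scatter, a modest loss of effect at the one concentration tested. Nothing at hand speaks to the reason for either step.

Open, as far as these compounds go, is whether a hydroxyl group, a chlorine atom or a longer chain such as ethoxy at this position would move the read-out beyond the scatter. From the compounds shown here alone, all three compounds show only a weak effect, so it also remains open whether any change on this ring can give a strong one.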